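Bromo in Place of Methyl: What to Expect of Compound 4

The source may report more compounds than this note shows. Statements on the series, on what has been measured and on what is new or still open speak of the compounds shown alone.

The study measures cytotoxicity in an ADME assay on Huh-7 cells (Homo sapiens) for cytotoxicity, read by MTT assay, with a stated time of 72 h; on this read-out higher numbers stand for lower toxicity in this test and lower numbers for higher toxicity in this test. Of the compounds shown here, three have been tested. Compound 1 `CN(O)C(=O)c1ccccc1O` reached only the limit of the assay, > 800000 nM, which is a limit and not a number. Compound 2 `COc1ccccc1C(=O)N(C)O` likewise reached > 800000 nM, again a limit rather than a number. Between them the step that the two limits leave unreadable from compound 1 to compound 2 cannot be read, since both ends sit at the limit of > 800000 nM in this assay, at which 2 of the 3 values shown sit. Among the compounds with values here, compound 3 `Cc1cccc(C(=O)NO)c1` is the one compound with an actual number: in this assay compound 3 gives 340000 nM, so it stands as the only readable value among the three.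

Compound 4 `O=C(NO)c1cccc(Br)c1` differs from compound 3 in one place: bromo in place of methyl on an aromatic carbon. Within the data shown here, no measured step bears on this exchange; the single step recorded, from one limit to another, has no readable size and involves a different change on an oxygen. There is therefore no ground for expecting a shift beyond the scatter in either direction, and the estimate for compound 4 is kept close to compound 3: the step of no change at the digits printed from compound 3 to compound 4 (within the scatter) is expected to be small. Compound 4 is estimated at 340000 nM, with a range from 120000 nM to 800000 nM.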

Compound 4, half-maximal cytotoxic concentration: 310000 nM
Compound 4: middle estimate off by 1.1-fold (0.04 log units), on the high side; measured number inside the range.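

In this assay, putting bromo in place of methyl on this aromatic carbon gives a 1.1-fold lower number from compound 3 to compound 4 (0.04 log units; within the scatter), so the two compounds cannot be told apart in this test. Within the data shown here, this is the first step in the set with a readable size, since the only earlier step runs between two limits and cannot be read, and it shows that this one exchange, at this one place on the six-membered aromatic ring, leaves the read-out within the usual scatter. Nothing at hand explains why the two groups match here, and the result assigns no property to either of them.

Methyl and bromo each bring a single heavy atom and no hydrogen-bond donors or acceptors, so it remains open whether an amine, a carboxylic acid or a longer chain on the same aromatic carbon would also stay within the scatter of compound 3. From the compounds shown here alone, it also remains open whether bromo in place of methyl would give so small a step on another carbon of the ring or on the core of compound 1.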